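The source may hold more compounds than are shown below. What is called first, only, known or untested is meant among the compounds shown, and "the series" means these compounds.

Compound 3 `CC1=C(/C=C/C(=O)/C=C/c2ccc(F)cc2)C(C)(C)CCC1`, compound 1 `CC1=C(/C=C/C(=O)/C=C/c2ccccc2)C(C)(C)CCC1` and compound 2 `CC1=C(/C=C/C(=O)/C=C/c2ccc(Br)cc2)C(C)(C)CCC1` share one core and differ only in the group on the far aromatic ring. In a functional assay on PC-3 cells (Homo sapiens) for cytotoxicity, read by sulforhodamine B assay, with a stated time of 48 h (on this read-out higher numbers stand for weaker inhibition and lower numbers for stronger inhibition), compound 3 gives 8200 nM, the lowest of the three numbers, while compound 1 gives 12400 nM and compound 2 gives 18900 nM. The gap a 1.5-fold lower number from compound 1 to compound 3 (0.18 log units; within the scatter) lies within the scatter, so compound 3 and compound 1 cannot be told apart; only the gap a 2.3-fold lower number from compound 2 to compound 3 (0.36 log units; beyond the scatter) is beyond it, and it is modest.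

Compound 4 `CC1=C(/C=C/C(=O)/C=C/c2ccc(C#N)cc2)C(C)(C)CCC1` arises from compound 3 by the change (cyano in place of fluoro on an aromatic carbon). Among the measured compounds shown here, no measured step involves a cyano group, so what can be used is how little this position has mattered so far: a 1.5-fold higher number from compound 1 to compound 2 (0.18 log units; within the scatter) and a 1.5-fold lower number from compound 1 to compound 3 (0.18 log units; within the scatter) both stayed within the scatter, and even a 2.3-fold lower number from compound 2 to compound 3 (0.36 log units; beyond the scatter) was only modest. A small step at most is therefore expected in this assay, without a clear direction.

Compound 4 is estimated at 9500 nM, with a plausible range from 3500 nM to 26000 nM. This estimate means a step of a 1.2-fold higher number from compound 3 to compound 4 (0.06 log units; within the scatter), which is expected to stay within the scatter.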

Compound 4, half-maximal inhibitory concentration: 11900 nM
The estimate for compound 4 lay 1.3-fold (0.10 log units) below the measured number; the measured number falls inside the stated range.
By their numbers in this assay, from the lowest: compounds 3, 4, 1 and 2 (each within the scatter of the next, the first and the last beyond it).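

Replacing fluoro with cyano brings in a triple bond and a hydrogen-bond acceptor, yet in this assay the result stays within the scatter (a 1.5-fold higher number from compound 3 to compound 4 (0.16 log units; within the scatter)). Cyano also cannot be told apart from bromo (a 1.6-fold lower number from compound 2 to compound 4 (0.20 log units; within the scatter)) or from hydrogen (a 1.0-fold lower number from compound 1 to compound 4 (0.02 log units; within the scatter)), so compound 4 sits within the scatter of all three earlier compounds, even though the bromo and fluoro compounds themselves stand modestly apart (a 2.3-fold lower number from compound 2 to compound 3 (0.36 log units; beyond the scatter)). The change in group type therefore gives no clear separation at this position in this cell assay, and no supporting measurement is available to explain that result.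

All four compounds differ only at this one place on the aromatic ring, para to a large group, and only hydrogen, fluoro, bromo and cyano are compared there. As far as these compounds go, it remains open whether an amine, a carboxylic acid or a longer chain at this place would produce a step clearly beyond the scatter, and whether changes elsewhere on the shared core would matter more.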